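The compounds below may be only part of what the source reports. "The series", "measured", "known", "first", "only" and "open" are said of these compounds alone.

Three compounds have been measured in a functional assay on HCT-116 cells (Homo sapiens) for cytotoxicity, read by sulforhodamine B assay, with a stated time of 72 h; a lower number here means a stronger inhibitor, a higher number a weaker inhibitor:

compound 1, `CCS(=O)(=O)Nc1cc(-c2ccc3ncnc(Nc4cccc(F)c4)c3c2)cnc1OC`, 3940 nM
compound 2, `CCS(=O)(=O)Nc1cc(-c2ccc3ncnc(Nc4ccc(F)cc4)c3c2)cnc1OC`, 3160 nM
compound 3, `CCS(=O)(=O)Nc1cc(-c2ccc3ncnc(Nc4cccc(C(=O)OC)c4)c3c2)cnc1OC`, 400 nM

Compound 3 stands at the lowest number of the three. The step of a 1.2-fold lower number from compound 1 to compound 2 (0.10 log units; within the scatter) is small, whereas a 9.9-fold lower number from compound 1 to compound 3 (0.99 log units; beyond the scatter) and a 7.9-fold lower number from compound 2 to compound 3 (0.90 log units; beyond the scatter) are both modest and beyond the scatter, so compound 3 is clearly separated from compounds 1 and 2.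

Compound 4, `CCS(=O)(=O)Nc1cc(-c2ccc3ncnc(Nc4ccc(F)c(C(=O)OC)c4)c3c2)cnc1OC`, differs from compound 3 in one place: fluoro in place of hydrogen on an aromatic carbon. Within the data shown here, none of the measured steps shows this exact change; the two steps that reach compound 3 exchange a fluoro for a methoxycarbonyl group or exchange the whole phenyl substituent, and neither adds a fluoro to a ring that already carries the ester. The data therefore give no direct guide, and the expectation rests on compound 3 itself. Compound 4 is expected to stay close to compound 3 in this assay, with a step of no change at the digits printed from compound 3 to compound 4 (within the scatter), within the scatter. The estimate for compound 4 is 400 nM, with a range from 150 nM to 1100 nM.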

Compound 4, half-maximal inhibitory concentration: 2360 nM
The estimate for compound 4 lay 5.9-fold (0.77 log units) below the measured number, outside the stated range (above it).
By their numbers in this assay, from the lowest: compound 3; then compounds 4, 2 and 1 (each within the scatter of the next).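

On the ring of compound 3, a fluoro ortho to a methoxycarbonyl group and para to a large group takes away most of the advantage that compound 3 held in this assay (a 5.9-fold higher number from compound 3 to compound 4 (0.77 log units; beyond the scatter)). Among these compounds, with the fluoro in place, the methoxycarbonyl group no longer separates the compounds: neither a 1.3-fold lower number from compound 2 to compound 4 (0.13 log units; within the scatter) nor a 1.7-fold lower number from compound 1 to compound 4 (0.22 log units; within the scatter) goes beyond the scatter, so the gain seen on the ring without fluoro does not carry over to the ring with it. Nothing available accounts for this reversal.

The compounds shown leave open whether the loss is particular to fluoro or would also come with a chloro or methyl group on that carbon. They also leave open whether a carboxylic acid or a primary amide in place of the methoxycarbonyl group would behave alike, with or without the fluoro.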